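Working notes: from compound 3 to compound 4

A few compounds are considered here, and "the series" means these few. Any claim that something is new, unique, unknown or untested is made for them only; others in the source may bear on it.

Measured in an ADME assay on HII4E cells (Mus musculus) for cytotoxicity, read by MTT assay, with a stated time of 48 h; a higher number here means a weaker inhibitor, a lower number a stronger inhibitor:
- compound 1 `CC(=O)OC[C@@H]1C=C(OC(C)=O)C(=O)[C@@H](OCC(=O)NCc2ccccc2)O1`: 163 ug/mL
- compound 2 `CCCCCCCCCCCCNC(=O)CO[C@H]1O[C@H](COC(C)=O)C=C(OC(C)=O)C1=O`: 136 ug/mL
- compound 3 `C=CCNC(=O)CO[C@H]1O[C@H](COC(C)=O)C=C(OC(C)=O)/C1=C\C(=O)OCC`: 352 ug/mL

Compound 3 holds the highest number of the three, and its gaps to compound 1 and to compound 2 both lie beyond the scatter.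

Compound 4 `CCOC(=O)/C=C1\C(OC(C)=O)=C[C@@H](COC(C)=O)O[C@@H]1OCC(=O)NCc1ccccc1` has not been measured. It departs from compound 3 by one change: phenyl in place of vinyl on a saturated chain carbon bound to an amide-type nitrogen. In words, this is phenyl in place of vinyl on a saturated chain carbon bound to an amide-type nitrogen, which also reads as allyl to benzyl.

For the measured compounds named here, only one measured step falls at this place: a 1.2-fold lower number from compound 1 to compound 2 (0.08 log units; within the scatter). It sets undecyl in place of phenyl, does not involve vinyl, and sits on the core of compound 1, which differs from that of compound 3. It is therefore indirect evidence, and it offers no sign of a large effect at this place. Compound 4 carries the same benzyl group as compound 1, and compound 1 gives 163 ug/mL, so a modest move toward lower numbers is allowed.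

In this assay the expected step is a 1.3-fold lower number from compound 3 to compound 4 (0.10 log units; within the scatter), and no shift beyond the scatter is expected. For compound 4 the estimated value is 280 ug/mL, with an expected range of 150 ug/mL to 500 ug/mL.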

Compound 4, half-maximal inhibitory concentration: 128 ug/mL
Compound 4: the middle estimate sits 2.2-fold (0.34 log units) above what was measured; measured number below the stated range.
By their numbers in this assay, from the lowest: compounds 4, 2 and 1 (each within the scatter of the next); then compound 3.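

In this assay, for the compounds shown here, the step of a 2.8-fold lower number from compound 3 to compound 4 (0.44 log units; beyond the scatter) is the first at this place to lie beyond the scatter, so the group on a saturated chain carbon bound to an amide-type nitrogen can shift the number on the core of compound 3. The earlier step at this place, undecyl in place of phenyl on the core of compound 1, gave a 1.2-fold lower number from compound 1 to compound 2 (0.08 log units; within the scatter) and did not show this. With phenyl in place of vinyl, read also as allyl to benzyl, compound 4 gives 128 ug/mL and stands within the scatter of compounds 1 and 2, leaving compound 3 alone at the high end, though the data offer no explanation for the step.

The compounds shown leave open whether the same change from allyl to benzyl would move the number on the core of compound 1, since this step rests on a single pair. They also leave open whether an undecyl chain on the core of compound 3, or a carboxylic acid or an amine on the phenyl group of compound 4, would keep the number where compound 4 stands.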